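The source may report more compounds than this note shows. Statements on the series, on what has been measured and on what is new or still open speak of the compounds shown alone.

Measured in a physicochemical assay for solubility, in simulated intestinal fluid, with a stated time of 4 h; on this read-out lower numbers stand for lower solubility and higher numbers for higher solubility:
Compound 1 `N#Cc1ccc(O[C@H]2CN(S(=O)(=O)c3ccccc3C#N)C[C@@]2(O)CO)cc1F`: 20 ug/mL
Compound 2 `N#Cc1ccc(O[C@H]2CN(S(=O)(=O)c3ccc(Cl)cc3)C[C@@]2(O)CO)cc1F`: 44 ug/mL

Compound 2 stands highest of the two at 44 ug/mL. Compound 3 `N#Cc1ccc(O[C@H]2CN(S(=O)(=O)c3ccc(C(F)(F)F)nc3)C[C@@]2(O)CO)cc1F` has 6-(trifluoromethyl)pyridin-3-yl in place of 4-chlorophenyl on a sulfonyl sulfur. Among the compounds with values here, one measured step bears on this, made on the same sulfonyl sulfur: a 2.2-fold higher number from compound 1 to compound 2 (0.34 log units; beyond the scatter), modest and beyond the scatter. That step exchanges other groups, so it gives no firm direction, and no step beyond the scatter is expected in this assay. The expected change is a 1.5-fold lower number from compound 2 to compound 3 (0.17 log units; within the scatter). Compound 3 is estimated at 30 ug/mL, with a range of 10 ug/mL to 90 ug/mL.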

Compound 3, solubility: 98 ug/mL
Compound 3: middle estimate off by 3.3-fold (0.51 log units), on the low side, and the stated range ends below it.
By their numbers in this assay, from the lowest: compound 1; then compound 2; then compound 3.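

In this assay, 6-(trifluoromethyl)pyridin-3-yl in place of 4-chlorophenyl on the sulfonyl sulfur gives a 2.2-fold higher number from compound 2 to compound 3 (0.35 log units; beyond the scatter), so the number at this position can rise further than the 4-chlorophenyl compound showed. Against 2-cyanophenyl, the same group gives a 4.9-fold higher number from compound 1 to compound 3 (0.69 log units; beyond the scatter), the widest step among these three compounds. No evidence at hand accounts for this rise.

The ring nitrogen and the trifluoromethyl enter together, and neither is seen alone. From the compounds shown here alone, how an aryl ring carrying an amine or a carboxylic acid would fare on this sulfur stays open.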